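Permeability notes: replacing the pyridinylmethyl side chain in the series

A few compounds are considered here, and "the series" means these few. Any claim that something is new, unique, unknown or untested is made for them only; others in the source may bear on it.

Three compounds in this series share a core built from a fused bicyclic proline-like amide and a chlorophenyl tetrazole benzylamide, and differ in the hydroxyacyl side chain. Compound 1 is `CC(C)(C)[C@@H](O)C(=O)N1[C@@H]2C[C@@H]2C[C@H]1C(=O)NCc1cc(Cl)ccc1-n1cnnn1`; in an ADME assay on Caco-2 cells (Homo sapiens) for permeability, read by LC-MS, in the apical to basolateral direction, with a stated time of 60 min, at pH 6.5 (on this read-out higher numbers stand for higher permeability and lower numbers for lower permeability), compound 1 gives 34 10^-6 cm/s. Compound 2 is `O=C(NCc1cc(Cl)ccc1-n1cnnn1)[C@@H]1[C@H]2C[C@H]2CN1C(=O)[C@H](O)CC1CC1`; in this assay compound 2 gives 3.4 10^-6 cm/s. Compound 3 is `O=C(NCc1cc(Cl)ccc1-n1cnnn1)[C@@H]1C[C@@H]2C[C@@H]2N1C(=O)[C@H](O)Cc1ccccn1`; in this assay compound 3 gives 1.2 10^-6 cm/s, the lowest of the three numbers, with compound 2 nearest and compound 1 furthest, both gaps beyond the scatter.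

The next compound, compound 4, is `COC(C)(C)[C@@H](O)C(=O)N1[C@H](C(=O)NCc2cc(Cl)ccc2-n2cnnn2)C[C@@H]2C[C@@H]21`. Its side chain differs from that of compound 3 as follows: 1-methoxy-1-methylethyl in place of (pyridin-2-yl)methyl on a saturated chain carbon bound to a carbonyl carbon and an oxygen on a saturated carbon. The closest analogy among measured compounds is compound 1, whose side chain also carries a branched saturated group on this carbon and which gives 34 10^-6 cm/s in this assay. Among the compounds with values here, no direct step between measured compounds isolates this change, so the expectation rests on that analogy and on the low number for compound 3.

For compound 4 the expected step of a 10-fold higher number from compound 3 to compound 4 (1.00 log units; beyond the scatter) is upward and beyond the scatter, though short of compound 1. Compound 4 is estimated at 12 10^-6 cm/s, within 4 10^-6 cm/s to 35 10^-6 cm/s.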

Compound 4, apparent permeability: 16 10^-6 cm/s
For compound 4 the middle estimate is 1.3-fold (0.12 log units) below the measured one, and the stated range covers the measured number.
By their numbers in this assay, from the lowest: compound 3; then compound 2; then compound 4; then compound 1.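

In this assay, within the data shown here, the side chain on this saturated chain carbon can be read on its own for the first time: 1-methoxy-1-methylethyl in place of (pyridin-2-yl)methyl gives a 13-fold higher number from compound 3 to compound 4 (1.12 log units; beyond the scatter), a large step with the rest of the structure unchanged. Compounds 1, 2 and 3 offered no such single-place comparison, so they could not tie any difference in the read-out to this position. The two groups have the same counts of hydrogen-bond donors and acceptors, so the step goes with the loss of the aromatic ring and a drop from 7 to 5 heavy atoms, not with a change in those counts, and no measurement shown gives a cause for it.

This single pair cannot separate the effect of the ring from that of the pyridine nitrogen, and a benzyl group on the same carbon would make that distinction. Nor does it show whether the branching or the ether oxygen of the entering group goes with the higher number, a question that an unbranched 2-methoxyethyl chain would address.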